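A nitrophenyl swap on the shared core

The source may report more compounds than this note shows. Statements on the series, on what has been measured and on what is new or still open speak of the compounds shown alone.

Compound 1 `CC1=CC[C@H]2[C@H](CC[C@]2(C)O)C(C)(C)[C@@H]1CC[C@H]1[C@]2(C)CC[C@H](OC(=O)c3ccccc3)C(C)(C)O[C@H]2CC[C@@]1(C)O`: 21000 nM
Compound 2 `CC1=CC[C@H]2[C@H](CC[C@]2(C)O)C(C)(C)[C@@H]1CC[C@H]1[C@]2(C)CC[C@H](OC(=O)NCc3ccccc3)C(C)(C)O[C@H]2CC[C@@]1(C)O`: 24500 nM
Compound 3 `CC1=CC[C@H]2[C@H](CC[C@]2(C)O)C(C)(C)[C@@H]1CC[C@H]1[C@]2(C)CC[C@H](OC(=O)c3ccc(Cl)c(Cl)c3)C(C)(C)O[C@H]2CC[C@@]1(C)O`: 11900 nM

In a functional assay on MCF7 cells (Homo sapiens) for antiproliferative activity, read by MTT assay, with a stated time of 72 h (on this read-out lower numbers stand for stronger inhibition and higher numbers for weaker inhibition), compound 3 gives the lowest of these three numbers, but the margins are small: a 1.8-fold lower number from compound 1 to compound 3 (0.25 log units; within the scatter), and a 2.1-fold lower number from compound 2 to compound 3 (0.31 log units; beyond the scatter). Compound 4 `CC1=CC[C@H]2[C@H](CC[C@]2(C)O)C(C)(C)[C@@H]1CC[C@H]1[C@]2(C)CC[C@H](OC(=O)c3cccc([N+](=O)[O-])c3)C(C)(C)O[C@H]2CC[C@@]1(C)O` changes the same place: 3-nitrophenyl in place of 3,4-dichlorophenyl on a carbonyl carbon. Both measured steps bear on this swap, since each changes the group on that carbonyl carbon. The first also exchanges one phenyl group for another. Among the measured compounds shown here, no measured compound carries a nitro group, so the direction is uncertain. In this assay the expected change is small, and none beyond the scatter is expected: a 1.3-fold higher number from compound 3 to compound 4 (0.13 log units; within the scatter). The estimated value for compound 4 is 16000 nM, with an expected range of 8000 nM to 32000 nM.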

Compound 4, half-maximal inhibitory concentration: 36000 nM
Beside the measured number, compound 4's estimate is 2.3-fold (0.35 log units) below it, and the stated range ends below it.
By their numbers in this assay, from the lowest: compounds 3, 1, 2 and 4 (each within the scatter of the next, the first and the last beyond it).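

In this assay, the choice between two substituted phenyl groups on this carbonyl carbon can shift the number: the change gives a 3.0-fold higher number from compound 3 to compound 4 (0.48 log units; beyond the scatter) and lies beyond the scatter. Yet nitro in place of hydrogen on the aromatic carbon gives only a 1.7-fold higher number from compound 1 to compound 4 (0.23 log units; within the scatter) and 3-nitrophenyl in place of benzylamino gives a 1.5-fold higher number from compound 2 to compound 4 (0.17 log units; within the scatter) so both of these steps stay within the scatter. The compounds shown leave open whether losing the two chlorines or gaining the nitro group matters more in the step from compound 3, and how a phenyl group bearing one chlorine or an amine would read. Nothing available explains these steps.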